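Changing the Group on the Ring Amine Nitrogen

A few compounds are considered here, and "the series" means these few. Any claim that something is new, unique, unknown or untested is made for them only; others in the source may bear on it.

Compound 1 `COc1cc(N2CCNCC2)ccc1Nc1nc(NC2CCCCC2)c2nc[nH]c2n1`: 88 nM
Compound 2 `COc1cc(N2CCN(C(=O)C3CCC(O)CC3)CC2)ccc1Nc1nc(NC2CCCCC2)c2nc[nH]c2n1`: 15 nM
Compound 3 `COc1cc(N2CCN(Cc3ccccn3)CC2)ccc1Nc1nc(NC2CCCCC2)c2nc[nH]c2n1`: 51 nM

In a functional assay on HCT-116 cells (Homo sapiens) for cytotoxicity (a higher number here means a weaker inhibitor, a lower number a stronger inhibitor), compound 3 gives 51 nM. That value lies within the scatter of compound 1, as a 1.7-fold lower number from compound 1 to compound 3 (0.24 log units; within the scatter) shows. The gap to compound 2 is clearer, with a 3.4-fold higher number from compound 2 to compound 3 (0.53 log units; beyond the scatter).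

The next compound, compound 4 `COc1cc(N2CCN(C(=O)N3CCC(O)C3)CC2)ccc1Nc1nc(NC2CCCCC2)c2nc[nH]c2n1`, has not yet been measured. The change is (3-hydroxypyrrolidin-1-yl)carbonyl in place of (pyridin-2-yl)methyl on an amine nitrogen in a ring.

Among the measured compounds shown here, the closest precedent is compound 2, which also has a carbonyl-linked ring bearing a hydroxy group, (4-hydroxycyclohexyl)carbonyl. Its step from the unsubstituted amine was a 5.9-fold lower number from compound 1 to compound 2 (0.77 log units; beyond the scatter), while the (pyridin-2-yl)methyl group of compound 3 gave no change beyond the scatter. For the measured compounds named here, this is a single precedent, and no measured compound carries the (3-hydroxypyrrolidin-1-yl)carbonyl group, so the reading across is uncertain. A modest step towards a lower number in this assay is therefore expected, similar in direction to the gap between compound 3 and compound 2. The expected step is a 2.3-fold lower number from compound 3 to compound 4 (0.37 log units; beyond the scatter). For compound 4 the estimated value is 22 nM, with an expected range of 7 nM to 70 nM.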

Compound 4, half-maximal inhibitory concentration: 27 nM
For compound 4 the middle estimate is 1.2-fold (0.09 log units) below the measured one, within the range that was stated.
By their numbers in this assay, from the lowest: compounds 2, 4, 3 and 1 (each within the scatter of the next, the first and the last beyond it).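

In this assay the (3-hydroxypyrrolidin-1-yl)carbonyl group on the amine nitrogen in a ring gives a 3.3-fold lower number from compound 1 to compound 4 (0.51 log units; beyond the scatter) and so joins the (4-hydroxycyclohexyl)carbonyl group of compound 2 as a second carbonyl-linked group whose step from the free amine lies beyond the scatter. Among the compounds shown here, exchanging 4-hydroxycyclohexyl for 3-hydroxypyrrolidin-1-yl on the carbonyl carbon gives a 1.8-fold higher number from compound 2 to compound 4 (0.26 log units; within the scatter) and shows that the ring on that carbonyl can go from six-membered to five-membered with no step that stands out from the scatter. Replacing (pyridin-2-yl)methyl gives a 1.9-fold lower number from compound 3 to compound 4 (0.28 log units; within the scatter) and therefore does not separate these two groups, although only compound 4, and not compound 3, stands beyond the scatter from compound 1.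

The data shown here give no explanation for any of these steps. Going by these compounds, it remains open whether the hydroxy group counts for anything at this position, as each carbonyl-linked ring here carries one, and an unsubstituted pyrrolidin-1-ylcarbonyl group or a plain acetyl group on the same nitrogen would address that question.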